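From Phenyl to Furan-2-yl on a Saturated Ring Carbon

This account rests on a few compounds, and the source may have more. Where it says the series, first, only, none or still open, it means among the compounds named here.

Compound 1 `CCn1cc(C(=O)N2N=C(c3cc4ccccc4o3)CC2c2ccccc2O)c(=O)c2ccc(C)nc21`: in an ADME assay on Vero cells (Chlorocebus sabaeus) for cytotoxicity, read by MTT assay, with a stated time of 72 h (on this read-out higher numbers stand for weaker inhibition and lower numbers for stronger inhibition), compound 1 gives > 157000 nM, which is a limit of the assay.
Compound 2 `CCn1cc(C(=O)N2N=C(c3cc4ccccc4o3)CC2c2ccccc2)c(=O)c2ccc(C)nc21`: in this assay compound 2 gives > 210000 nM, again a limit rather than a number.

Compound 2 therefore stands at the top of what this assay can report, with no measured number to place it. The one step measured so far, a step that the two limits leave unreadable from compound 1 to compound 2, cannot be read, because both ends are limits, as shown by the limit of > 157000 nM in this assay, at which 1 of the 2 values shown sits, and (the limit of > 210000 nM in this assay, at which 1 of the 2 values shown sits). Compound 3 `CCn1cc(C(=O)N2N=C(c3cc4ccccc4o3)CC2c2ccco2)c(=O)c2ccc(C)nc21` carries the change (furan-2-yl in place of phenyl on a saturated ring carbon), that is, furan-2-yl in place of phenyl on a saturated ring carbon. Among the compounds with values here, no measured step shows what such a swap does in this assay, so no shift beyond the usual scatter is expected, and an at least 1.0-fold lower number from compound 2 to compound 3 (0.02 log units; that floor lies within the scatter) is the step that is estimated. Compound 3 is expected to give about 200000 nM, within 50000 nM to 500000 nM, most likely again reported only as a limit.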

Compound 3, half-maximal inhibitory concentration: > 185000 nM
Compound 3: only a limit was reported; the forecaster's own chance of this, stated with the estimate: 75%; the middle value does not contradict the limit.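

Compound 1, compound 2 and compound 3 all give only limits in this assay, so the steps among these three compounds cannot be read. The compounds shown leave open whether 2-hydroxyphenyl, phenyl or furan-2-yl on the saturated ring carbon makes any difference in this assay.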